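Bromo for Chloro on the Aryl Ring of Compound 3

The compounds below may be only part of what the source reports. "The series", "measured", "known", "first", "only" and "open" are said of these compounds alone.

Three compounds have been measured in a functional assay on SF-268 cells (Homo sapiens) for inhibition, read by sulforhodamine B assay, with a stated time of 48 h, tested at 10 uM; on this read-out lower numbers stand for less inhibition and higher numbers for more inhibition at the one concentration tested (going by the name of the read-out):

Compound 1, `COc1ccc(-c2cn3ccnc3c(-c3ccc4ncn(C5CCCCC5)c4c3)n2)cc1`, gives 49.9%.
Compound 2, `c1ccc2c(-c3cn4ccnc4c(-c4ccc5ncn(C6CCCCC6)c5c4)n3)cccc2c1`, gives 7.84%.
Compound 3, `Clc1ccc(-c2cn3ccnc3c(-c3ccc4ncn(C5CCCCC5)c4c3)n2)cc1`, gives 4.83%.

Compound 3 holds the lowest of the three numbers. The distance to compound 1 is large: the step of a number 45.1 percentage points lower from compound 1 to compound 3 (beyond the scatter) lies well beyond the scatter, as does a number 42.1 percentage points lower from compound 1 to compound 2 (beyond the scatter). The distance to compound 2 is not: the step of a number 3 percentage points lower from compound 2 to compound 3 (within the scatter) is within the scatter, so compound 2 and compound 3 cannot be told apart on these numbers.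

Compound 4, `Brc1ccc(-c2cn3ccnc3c(-c3ccc4ncn(C5CCCCC5)c4c3)n2)cc1`, is compound 3 with one change: bromo in place of chloro on an aromatic carbon. For the measured compounds named here, no measured step swaps one halogen for another, so the closest guidance comes from a number 3 percentage points lower from compound 2 to compound 3 (within the scatter), where two quite different groups at the same position both left the number low, and from a number 45.1 percentage points lower from compound 1 to compound 3 (beyond the scatter), where only the methoxy group stood out with a high number. Replacing chloro with bromo is a smaller change than either of those. The expected step of a number 2.2 percentage points higher from compound 3 to compound 4 (within the scatter) is therefore none beyond the scatter. Compound 4 is estimated to give 7%, with a likely range from 0% to 20%.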

Compound 4, a percentage reported as inhibition, at one concentration (the size of the read-out at that concentration, not a potency): 15.5%
Estimate against measurement, compound 4: 8.5 percentage points below; measured number inside the range.
By their numbers in this assay, from the lowest: compounds 3, 2 and 4 (each within the scatter of the next, the first and the last beyond it); then compound 1.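

For the compounds shown here, the first swap of one halogen for another at this position shows that a single-atom change on the 4-halophenyl ring can register in this assay, with a number 10.7 percentage points higher from compound 3 to compound 4 (beyond the scatter). Replacing the naphthalen-1-yl group with 4-bromophenyl gives a number 7.7 percentage points higher from compound 2 to compound 4 (within the scatter), while replacing methoxy with bromo gives a number 34.4 percentage points lower from compound 1 to compound 4 (beyond the scatter), so the low-reading compounds do not form one clean level, yet the methoxy compound still stands apart from all of them. No measurement available here accounts for the difference between the chloro and bromo compounds.

Going by these compounds, it remains open whether the higher number of compound 1 is peculiar to methoxy or extends to related groups, such as ethoxy, hydroxy or dimethylamino, at the same place on the ring. Fluoro and iodo would show whether the step from chloro to bromo continues along the halogens, and readings at several concentrations would be needed to show how the effect changes with concentration, since these numbers give only the size of the effect at the one concentration tested.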